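Methoxy for Fluoro on a Cytotoxicity Read-out

The compounds below may be only part of what the source reports. "The series", "measured", "known", "first", "only" and "open" are said of these compounds alone.

Measured so far:
compound 1, `Fc1ccc(-c2nn3c(NC4CCCC4)cccc3c2-c2ccnc(NC3CCCC3)n2)cc1`: > 160000 nM
compound 2, `Fc1ccc(-c2nn3c(NC4CCCC4)nccc3c2-c2ccnc(NC3CCCC3)n2)cc1`: > 40000 nM
compound 3, `COc1ccc(-c2nn3c(NC4CCCC4)nccc3c2-c2ccnc(NC3CCCC3)n2)cc1`: > 40000 nM

In an ADME assay on Vero cells (Chlorocebus sabaeus) for cytotoxicity (on this read-out lower numbers stand for higher toxicity in this test and higher numbers for lower toxicity in this test), compound 1 gives no number but only a limit, > 160000 nM. Compound 2 likewise gives only a limit, > 40000 nM. Compound 3 also gives only a limit, > 40000 nM. Compound 3 differs from compound 2 by methoxy in place of fluoro on an aromatic carbon, and the step that the two limits leave unreadable from compound 2 to compound 3. How the cores of compound 1 and compound 2 differ is not broken down here.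

Compound 4, `COc1ccc(-c2nn3c(NC4CCCC4)cccc3c2-c2ccnc(NC3CCCC3)n2)cc1`, is not yet measured; it differs from compound 1 by the same change, (methoxy in place of fluoro on an aromatic carbon). The step is expected to be a step that the limit leaves unreadable from compound 1 to compound 4, which rests on compound 1 standing at the limit of > 160000 nM in this assay, at which 1 of the 3 values shown sits, and on the unreadable step between compound 2 and compound 3. Compound 4 is therefore expected to give 200000 nM, most likely again reported only as a limit.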

Compound 4, half-maximal cytotoxic concentration: > 100000 nM
Compound 4: only a limit was reported (the forecaster's own chance of this, stated with the estimate: 85%); the middle value is on the limit's open side.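

Among these compounds, compound 1 and compound 4 both give only limits in this assay, so no step between them can be read. The compounds shown leave open whether methoxy in place of fluoro shifts this read-out at all, on either core.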